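Notes on the step from compound 3 to compound 4

A few compounds are considered here, and "the series" means these few. Any claim that something is new, unique, unknown or untested is made for them only; others in the source may bear on it.

Measured in a functional assay on ECa-109 cells (Homo sapiens) for inhibition, read by MTT assay, with a stated time of 72 h; on this read-out higher numbers stand for weaker inhibition and lower numbers for stronger inhibition:
compound 1 `Cc1ccc(Cn2cc(CSC(=S)N3CCN(C(=O)OC(C)(C)C)CC3)nn2)cc1` — 47900 nM
compound 2 `Fc1ccccc1Cn1cc(CSC(=S)N2CCNCC2)nn1` — > 128000 nM, a limit of the assay
compound 3 `S=C(SCc1cn(Cc2ccc(Cl)cc2)nn1)N1CCNCC1` — > 128000 nM, a limit of the assay

Compound 3 stands at the limit of this assay; its value > 128000 nM is a limit, not a number. Compound 2 likewise gives only the limit > 128000 nM. Of the three values shown, the picture is the limit of > 128000 nM in this assay, at which 2 of the 3 values shown sit. Among the compounds with values here, compound 1 carries the one numbered value, 47900 nM; it differs from compound 4 in more than one place, so it frames no single step. Within the data shown here, the only measured step reaching compound 3 is a step that the two limits leave unreadable from compound 2 to compound 3, and it carries no readable size.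

Compound 4 `Cc1ccc(Cn2cc(CSC(=S)N3CCNCC3)nn2)cc1` is not yet measured in this assay. It differs from compound 3 by methyl in place of chloro on an aromatic carbon. Among the measured compounds shown here, no measured step in this assay shows a change of this kind, so no direction can be read for it; the comparison of compound 2 with compound 3 only shows that one exchange on the same ring left both at the limit.

Compound 4 is therefore expected to sit close to compound 3, with an expected step that the limit leaves unreadable from compound 3 to compound 4, most likely again reported as a limit rather than a number. The estimate for compound 4 in this assay is 150000 nM, expected within 50000 nM to 500000 nM.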

Compound 4, half-maximal inhibitory concentration: > 128000 nM
Compound 4 was reported as a limit (the forecaster's own chance of this, stated with the estimate: 70%); the middle value is on the limit's open side.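

In this assay, within the data shown here, hydrogen in place of tert-butoxycarbonyl on the amine nitrogen in the ring gives an at least 2.6-fold higher number from compound 1 to compound 4 (0.42 log units; beyond the scatter), the only readable step and the first sign that this nitrogen position matters. The steps reaching compound 4 from compound 2 and from compound 3 cannot be read, since both ends of each are limits, so the exchange of chloro for methyl on the aromatic carbon has no measurable size. Compound 2, compound 3 and compound 4 all carry hydrogen on that nitrogen and all stand at a limit, with compound 1, which keeps the tert-butoxycarbonyl group, the one exception: the limit of > 128000 nM in this assay, at which 3 of the 4 values shown sit.

Differences among 2-fluorophenyl, 4-chlorophenyl and 4-methylphenyl remain hidden behind the limit, and the compounds shown give no comparison of these rings with the tert-butoxycarbonyl group in place. As far as these compounds go, it also remains open whether another group on the ring nitrogen, such as an acetyl group or a longer alkyl chain, would give a numbered value like that of compound 1.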